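A few compounds are considered here, and "the series" means these few. Any claim that something is new, unique, unknown or untested is made for them only; others in the source may bear on it.

Two close relatives of one shared core have been tested in a functional assay on NCI-H292 cells (Homo sapiens) for cytotoxicity, read by MTT assay, with a stated time of 72 h, tested at 5 ug/mL; on this read-out lower numbers stand for less inhibition of growth and higher numbers for more inhibition of growth at the one concentration tested. In that test compound 1 `O=C1NC(=S)/C(=C/c2ccc(Cl)cc2)S1` gives 35.8%, and compound 2 `O=C1NC(=S)/C(=C/c2cccc(Cl)c2)S1` gives 21.6%. Compound 2 therefore stands lowest of the two numbers, with compound 1 the nearer of the pair, higher by an amount beyond the usual scatter. Compound 3 `O=C1NC(=S)/C(=C/c2ccc(Cl)c(Cl)c2)S1` differs from compound 2 by chloro in place of hydrogen on an aromatic carbon, a chloro in place of hydrogen on an aromatic carbon. For the measured compounds named here, no such step has been measured here, so the expectation rests only on those two numbers. For compound 3 a moderate rise is expected, a number 18.4 percentage points higher from compound 2 to compound 3 (beyond the scatter). Compound 3 is thus estimated at about 40%, within a range from 20% to 60%.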

Compound 3, percent growth inhibition at one concentration: 35.8%
Estimate against measurement, compound 3: 4.2 percentage points above; measured number inside the range.
By their numbers in this assay, from the lowest: compound 2; then compounds 1 and 3 (each within the scatter of the next).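

Chloro in place of hydrogen on the aromatic carbon para to the group of 8 heavy atoms gives a number 14.2 percentage points higher from compound 2 to compound 3 (beyond the scatter) in this assay. The same swap on the other chlorinated carbon of compound 3 gives no change at the digits printed from compound 1 to compound 3 (within the scatter), so among these compounds the two places do not count alike. Nothing available here explains that difference. On these data alone, whether a fluoro, a methyl or a methoxy on the first carbon would give a number like that of chloro stays open.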